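A few compounds are considered here, and "the series" means these few. Any claim that something is new, unique, unknown or untested is made for them only; others in the source may bear on it.

Compound 2 `Clc1ccc2c(NCCCNc3nccc(Nc4ccccc4)n3)ccnc2c1` is the starting point of this account. Within the data shown here, in an ADME assay on Vero cells (Chlorocebus sabaeus) for cytotoxicity, read by neutral red uptake, with a stated time of 72 h (on this read-out lower numbers stand for stronger inhibition and higher numbers for weaker inhibition), compound 2 gives 12800 nM, the only number reported, whereas compound 1 `Fc1ccc(Nc2ccnc(NCCNc3ccnc4cc(Cl)ccc34)n2)cc1` is recorded in this assay merely as "not active" (no number reported), without a figure. Compound 3 `Cc1ccc(Nc2ccnc(NCCCNc3ccnc4cc(Cl)ccc34)n2)cc1` differs from compound 2 by methyl in place of hydrogen on an aromatic carbon. Among the measured compounds shown here, no measured pair shows what such a change does here. The step is expected to stay within the usual scatter, so that a 1.1-fold lower number from compound 2 to compound 3 (0.03 log units; within the scatter) is estimated to be small in either direction. Compound 3 is therefore expected to give about 12000 nM in this assay, with a likely range from 5000 nM to 30000 nM.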

Compound 3, half-maximal inhibitory concentration: 18500 nM
Compound 3: the middle estimate sits 1.5-fold (0.19 log units) below what was measured; measured number inside the range.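

In this assay, among these compounds, the change from phenyl to 4-methylphenyl gives a 1.4-fold higher number from compound 2 to compound 3 (0.16 log units; within the scatter) as the first measured step at this position, on an aromatic carbon para to a large group. A single methyl here thus leaves the two compounds within the usual scatter of each other in this assay. Nothing available bears on why this is so. From the compounds shown here alone, it remains open what a carboxylic acid, an amine or a methoxy group at this same place would do to the number. Going by these compounds, whether a longer chain between the two ring systems would shift it also remains open.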